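Methoxy for Methyl on a Shared Scaffold

The source may hold more compounds than are shown below. What is called first, only, known or untested is meant among the compounds shown, and "the series" means these compounds.

Compound 1 `OC[C@@]1(c2ccc(F)cc2)NC[C@@H](O)[C@@H]1O`: 0%
Compound 2 `Cc1ccc([C@]2(CO)NC[C@@H](O)[C@@H]2O)cc1`: 1.6%
Compound 3 `CCCCCCCCC[C@]1(CO)NC[C@@H](O)[C@@H]1O`: 2.5%

Of the compounds shown here, three sharing one core have been tested in an assay on isolated protein for inhibition of alpha-galactosidase (Coffea arabica), tested at 1000 uM; a higher number here means more inhibition at the concentration tested (going by the name of the read-out), a lower number less inhibition. In this assay compound 1 gives 0%, compound 2 gives 1.6%, and compound 3 gives 2.5%. On these numbers compound 2 is the second highest of three, with compound 3 nearest and compound 1 furthest, but both gaps lie within the scatter, so the three compounds cannot be told apart by this assay.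

Compound 4 `COc1ccc([C@]2(CO)NC[C@@H](O)[C@@H]2O)cc1` differs from compound 2 in one place: methoxy in place of methyl on an aromatic carbon. For the measured compounds named here, the only measured step at that same aromatic carbon is a number 1.6 percentage points higher from compound 1 to compound 2 (within the scatter), and it stayed within the scatter. Going by the values given here, no measured step involves a methoxy group, so nothing points to a change beyond the scatter. Compound 4 is therefore expected to stay near the level of the three measured compounds, with a step of a number 0.4 percentage points higher from compound 2 to compound 4 (within the scatter). The estimate for compound 4 in this assay is 2%, between 0% and 12%.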

Compound 4, a percentage reported as inhibition, at one concentration (the size of the read-out at that concentration, not a potency): 7.5%
Estimate against measurement, compound 4: 5.5 percentage points below, and the stated range covers the measured number.
By their numbers in this assay, from the lowest: compounds 1, 2, 3 and 4 (each within the scatter of the next).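

In this assay, methoxy in place of methyl gives a number 5.9 percentage points higher from compound 2 to compound 4 (within the scatter), and methoxy in place of fluoro gives a number 7.5 percentage points higher from compound 1 to compound 4 (within the scatter), so neither change at this aromatic carbon separates the compounds. The earlier compounds shown here covered only fluoro and methyl at this position, and the result adds a group with one more heavy atom and one hydrogen-bond acceptor, yet all three groups remain indistinguishable in this measurement. Nothing available explains the number for compound 4.

On these data alone, what remains open is whether any group on this aromatic carbon can produce a step beyond the scatter, for example an amine or a carboxylic acid. A longer chain on the oxygen of the methoxy group, such as ethoxy, poses the same question.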